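Swapping the aryl group on the piperazine of compound 3

A few compounds are considered here, and "the series" means these few. Any claim that something is new, unique, unknown or untested is made for them only; others in the source may bear on it.

Measured so far, in an assay on HEK293 cells for displacement of a labelled ligand from 5-hydroxytryptamine receptor 7 (Homo sapiens); on this read-out higher numbers stand for weaker inhibition and lower numbers for stronger inhibition:
- compound 1 `CC1(c2ccc(F)cc2)NC(=O)N(CC(O)CN2CCN(c3ccccc3F)CC2)C1=O` gives 234 nM
- compound 2 `CC1(c2ccc(F)cc2)NC(=O)N(CC(O)CN2CCN(c3ccc(F)cc3)CC2)C1=O` gives 837 nM
- compound 3 `CC1(c2ccc(F)cc2)NC(=O)N(CC(O)CN2CCN(c3ccc(F)cc3F)CC2)C1=O` gives 1190 nM

Compound 3 stands at the highest number of the three: the gap to compound 2 lies within the scatter, while the step of a 5.1-fold higher number from compound 1 to compound 3 (0.71 log units; beyond the scatter) lies beyond it. Compound 4 `Cc1ccc(N2CCN(CC(O)CN3C(=O)NC(C)(c4ccc(F)cc4)C3=O)CC2)cc1C` differs from compound 3 by 3,4-dimethylphenyl in place of 2,4-difluorophenyl on an amine nitrogen in a ring. Among the compounds with values here, two measured steps bear on this aryl group: a 3.6-fold higher number from compound 1 to compound 2 (0.55 log units; beyond the scatter) and a 1.4-fold higher number from compound 2 to compound 3 (0.15 log units; within the scatter). Within the data shown here, no measured step shows a methyl on this aryl group, so the direction of the change is uncertain. Compound 4 is therefore expected to stay near compound 3, with a 1.3-fold lower number from compound 3 to compound 4 (0.12 log units; within the scatter) expected to lie within the scatter. The estimate for compound 4 is 900 nM, in a range from 300 nM to 3000 nM.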

Compound 4, inhibition constant: 177 nM
Beside the measured number, compound 4's estimate is 5.1-fold (0.71 log units) above it; the whole stated range lies above it.
By their numbers in this assay, from the lowest: compounds 4 and 1 (each within the scatter of the next); then compounds 2 and 3 (each within the scatter of the next).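

In this assay, the result shows that this aryl group on the ring nitrogen needs no fluorine to give a low number: 3,4-dimethylphenyl brings a 6.7-fold lower number from compound 3 to compound 4 (0.83 log units; beyond the scatter) when it replaces 2,4-difluorophenyl and a 4.7-fold lower number from compound 2 to compound 4 (0.67 log units; beyond the scatter) when it replaces 4-fluorophenyl. Against 2-fluorophenyl the same group gives a 1.3-fold lower number from compound 1 to compound 4 (0.12 log units; within the scatter) and so cannot be told apart from it. Nothing available explains these differences. On these data alone, whether both methyls are needed remains open, as does how a chloro or methoxy group on this aromatic ring would read.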